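The source may report more compounds than this note shows. Statements on the series, on what has been measured and on what is new or still open speak of the compounds shown alone.

In a functional assay on CCRF-CEM cells (Homo sapiens) for cytotoxicity, read by MTT assay, with a stated time of 24 h, tested at 20 uM (on this read-out lower numbers stand for a stronger effect and higher numbers for a weaker effect at the one concentration tested), compound 2 `N#CCCn1cnc2c(Br)c(Br)c(Br)c(Br)c21` gives 44%. Within the data shown here, its only companion is compound 1 `Cc1nc2c(Br)c(Br)c(Br)c(Br)c2n1CCC#N`, which gives 51%, and the step of a number 7 percentage points lower from compound 1 to compound 2 (within the scatter) leaves the two within the scatter of each other. Compound 3 `N#CCCCCn1cnc2c(Br)c(Br)c(Br)c(Br)c21` differs from compound 2 by 2-cyanoethyl in place of cyano on a saturated chain carbon, two bonds along the chain from an aromatic nitrogen. Among the measured compounds shown here, no measured step touches the chain on the ring nitrogen; the one known step concerns a methyl on an aromatic carbon and was small. Lacking any bearing comparison, the step of no change at the digits printed from compound 2 to compound 3 (within the scatter) is expected to stay within the scatter, so compound 3 is estimated at 44%, between 25% and 65%.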

Compound 3, a percentage reported as activity, at one concentration (the size of the read-out at that concentration, not a potency): 70%
For compound 3 the middle estimate is 26 percentage points below the measured one, outside the stated range (above it).
By their numbers in this assay, from the lowest: compounds 2 and 1 (each within the scatter of the next); then compound 3.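

In this assay, replacing cyano with 2-cyanoethyl on a saturated chain carbon, two bonds along the chain from an aromatic nitrogen, gives a number 26 percentage points higher from compound 2 to compound 3 (beyond the scatter) and thus a weaker effect at the one concentration tested. Among these compounds, this is the first step beyond the scatter, and it shows that the chain on the ring nitrogen is not a neutral place for change. Nothing available explains the loss. Still open, from the compounds shown here alone, is whether an amine or a carboxylic acid in place of the nitrile would restore the effect. Also open, going by these compounds, is whether the methyl of compound 1 would matter on the longer chain.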